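Shortening the chain on the core nitrogen: compound 3 to compound 4

The source may report more compounds than this note shows. Statements on the series, on what has been measured and on what is new or still open speak of the compounds shown alone.

Three compounds share a core and differ only in the group on a saturated chain carbon bound to an aromatic nitrogen. In a functional assay on MCF7 cells (Homo sapiens) for antiproliferative activity (a lower number here means a stronger inhibitor, a higher number a weaker inhibitor), compound 1 `COc1cc(Cc2nc3c(N)ncnc3n2CC2CCC2)cc(OC)c1OC` gives 45700 nM, compound 2 `COc1cc(Cc2nc3c(N)ncnc3n2CC2CC2)cc(OC)c1OC` gives 75900 nM, and compound 3 `C/C=C/Cn1c(Cc2cc(OC)c(OC)c(OC)c2)nc2c(N)ncnc21` gives 51300 nM. Compound 3 thus stands second highest of the three numbers, and all three sit close together: the step of a 1.7-fold higher number from compound 1 to compound 2 (0.22 log units; within the scatter), the step of a 1.1-fold higher number from compound 1 to compound 3 (0.05 log units; within the scatter) and the step of a 1.5-fold lower number from compound 2 to compound 3 (0.17 log units; within the scatter) are each within the scatter, so swapping cyclobutyl, cyclopropyl and prop-1-en-1-yl at this place has made no real difference.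

Compound 4 `COc1cc(Cc2nc3c(N)ncnc3n2C)cc(OC)c1OC` is not yet measured. It differs from compound 3 as follows: hydrogen in place of prop-1-en-1-yl on a saturated chain carbon bound to an aromatic nitrogen. The three measured steps bear on this change, since each alters the same group at the same place, and none moved the number beyond the scatter. The shortened chain is therefore expected to leave the result much where it is, with the step of a 1.2-fold higher number from compound 3 to compound 4 (0.07 log units; within the scatter) reflecting that expectation. Compound 4 is estimated at 60000 nM in this assay, within a range from 25000 nM to 150000 nM.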

Compound 4, half-maximal inhibitory concentration: 70800 nM
Estimate against measurement, compound 4: 1.2-fold (0.07 log units) below, within the range that was stated.
By their numbers in this assay, from the lowest: compounds 1, 3, 4 and 2 (each within the scatter of the next).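

Cutting the group at this place down to a bare methyl, with hydrogen in place of prop-1-en-1-yl, still gives only a 1.4-fold higher number from compound 3 to compound 4 (0.14 log units; within the scatter) in this assay and so makes no real difference. The comparisons with the ring-bearing groups agree, with a 1.1-fold lower number from compound 2 to compound 4 (0.03 log units; within the scatter) and a 1.5-fold higher number from compound 1 to compound 4 (0.19 log units; within the scatter) as the other two steps. Across these four compounds, then, neither the extra chain carbons, the double bond nor a ring on a saturated chain carbon bound to an aromatic nitrogen shifts the number beyond the scatter, and no measurement shown explains this.

Still open, going by these compounds, is whether a longer chain, or a chain ending in an amine or a carboxylic acid, would move the number at this place. Also open, on these data alone, is whether changes elsewhere on the shared core would matter more.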